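One Substituent Swap, Measured Once and Expected Again

This account rests on a few compounds, and the source may have more. Where it says the series, first, only, none or still open, it means among the compounds named here.

Compound 1 `O=S(=O)(c1ccccc1)c1nc2ccccc2nc1Nc1ccc(Cl)cc1` and compound 2 `O=S(=O)(c1ccccc1)c1nc2ccccc2nc1Nc1ccc(C(F)(F)F)cc1` share a core and differ in a single place: trifluoromethyl in place of chloro on an aromatic carbon. In a functional assay on PC-3 cells (Homo sapiens) for cytotoxicity, read by MTT assay, with a stated time of 72 h (on this read-out higher numbers stand for weaker inhibition and lower numbers for stronger inhibition), compound 1 gives 15300 nM, while compound 2 gives 3550 nM. That single change produced a 4.3-fold lower number from compound 1 to compound 2 (0.63 log units; beyond the scatter), so the trifluoromethyl compound returned the stronger inhibition of the pair.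

Compound 3 `Cc1ccc(S(=O)(=O)c2nc3ccccc3nc2Nc2ccc(Cl)cc2)cc1` carries a core that differs from the core of compound 1 in one counted way: methyl in place of hydrogen on an aromatic carbon. In this assay compound 3 gives 9660 nM, and the step of a 1.6-fold lower number from compound 1 to compound 3 (0.20 log units; within the scatter) is too small to read as a real difference between compound 1 and compound 3.

Compound 4 `Cc1ccc(S(=O)(=O)c2nc3ccccc3nc2Nc2ccc(C(F)(F)F)cc2)cc1` has not yet been measured. It differs from compound 3 by trifluoromethyl in place of chloro on an aromatic carbon, which is the same change that separates compound 1 from compound 2, with the place described in the same words for both pairs. The only other difference between the two pairs is the core change already described.

Compound 4 is expected to give roughly 2300 nM in this assay, meaning an expected step of a 4.2-fold lower number from compound 3 to compound 4 (0.62 log units; beyond the scatter). This expectation rests on the measured pair, because a 4.3-fold lower number from compound 1 to compound 2 (0.63 log units; beyond the scatter) was seen when the identical swap was made on the core of compound 1, and the small core difference gives no reason to expect a different outcome. Given the usual scatter and only one prior example of the swap, compound 4 is estimated to fall between 1000 nM and 5500 nM.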

Compound 4, half-maximal inhibitory concentration: 2540 nM
Compound 4: middle estimate off by 1.1-fold (0.04 log units), on the low side, and the stated range covers the measured number.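

Replacing chloro with trifluoromethyl on the core of compound 3 gave a 3.8-fold lower number from compound 3 to compound 4 (0.58 log units; beyond the scatter), and this matches what the same swap did on the core of compound 1: the same change on two cores in this assay, a 4.3-fold lower number (0.63 log units; beyond the scatter) from compound 1 to compound 2 and a 3.8-fold lower number (0.58 log units; beyond the scatter) from compound 3 to compound 4, 1.1-fold (0.05 log units) apart, within the scatter of two such steps. Adding the methyl to the trifluoromethyl compound gave a 1.4-fold lower number from compound 2 to compound 4 (0.15 log units; within the scatter), a step too small to count as a real difference, and the methyl step looks the same with either group in place: the same change on two cores in this assay, a 1.6-fold lower number (0.20 log units; within the scatter) from compound 1 to compound 3 and a 1.4-fold lower number (0.15 log units; within the scatter) from compound 2 to compound 4, 1.1-fold (0.05 log units) apart, within the scatter of two such steps. Among the compounds shown here, the agreement covers only two cores that differ by one methyl, all in this assay; it shows that the swap carried across this small core change, but not that it would carry to a more different core, and it does not explain why the number falls.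

The compounds shown leave open what other groups in place of chloro, such as a nitrile, an amine or a carboxylic acid, would do to the number. They also leave open whether a longer chain in place of the methyl would stay as close to the hydrogen compounds as the methyl does, and whether the same steps would appear in other cell lines.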